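Phenyl for methyl on the ring nitrogen of compound 3

A few compounds are considered here, and "the series" means these few. Any claim that something is new, unique, unknown or untested is made for them only; others in the source may bear on it.

The three measured compounds share a fused core bearing an amino group and a nitrile. In a functional assay on NCI-H2122 cells (Homo sapiens) for inhibition, read by microscopy, with a stated time of 10 days (on this read-out lower numbers stand for stronger inhibition and higher numbers for weaker inhibition), compound 1 `Cc1nn(C)c2c1C(c1ccccc1)C(C#N)=C(N)O2` gives 9100 nM. Compound 2 `Cn1nc(-c2ccccc2)c2c1OC(N)=C(C#N)C2c1ccccc1`, with phenyl in place of methyl on an aromatic carbon, reaches only the limit of the assay, > 10000 nM. Compound 3 `Cn1nc(-c2ccccc2)c2c1OC(N)=C(C#N)C2c1ccc(F)cc1` likewise sits at the limit, > 10000 nM. Compound 3 therefore stands at the weak end of what the numbers show, where the limit of > 10000 nM in this assay, at which 2 of the 3 values shown sit, marks the place of two of the three values.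

Compound 4 `N#CC1=C(N)Oc2c(c(-c3ccccc3)nn2-c2ccccc2)C1c1ccc(F)cc1` differs from compound 3 by phenyl in place of methyl on an aromatic nitrogen of the five-membered aromatic ring with two nitrogen, part of the fused system of two rings, next to the ring nitrogen and next to the ring atom that bears the fused ring.

For the measured compounds named here, the only step that bears on this is an at least 1.0-fold higher number from compound 1 to compound 2 (0.04 log units; that floor lies within the scatter), the same phenyl-for-methyl exchange on an aromatic carbon, which brought no gain. The step that the two limits leave unreadable from compound 2 to compound 3 cannot be sized. Compound 4 is expected to show a step that the limit leaves unreadable from compound 3 to compound 4, no move beyond the scatter. Compound 4 is estimated at 15000 nM, within 5000 nM to 40000 nM, most probably again only a limit.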

Compound 4, half-maximal inhibitory concentration: 4100 nM
Estimate against measurement, compound 4: 3.7-fold (0.56 log units) above, outside the stated range (below it).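

In this assay, the aromatic nitrogen of the five-membered ring proves to be a place where a change can be read: phenyl in place of methyl there gives an at least 2.4-fold lower number from compound 3 to compound 4 (0.38 log units; beyond the scatter). This is a floor and not a full size, since the starting point is only a limit, but it already lies beyond the scatter. The same exchange of phenyl for methyl on an aromatic carbon brought no move beyond the scatter, so the two places do not answer alike, and compound 4 is the only one of the compounds carrying the phenyl on that aromatic carbon to give a number rather than a limit: the limit of > 10000 nM in this assay, at which 2 of the 4 values shown sit.

The compounds shown leave open how the nitrogen tolerates other groups, for instance whether ethyl, a benzyl group, or a phenyl ring carrying methoxy or an amine would keep, extend or lose the gain. They also leave open whether the gain on this nitrogen holds with hydrogen in place of fluoro on the other phenyl ring, and how large the step really is.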